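The source may hold more compounds than are shown below. What is called first, only, known or untested is meant among the compounds shown, and "the series" means these compounds.

Measured so far, in an assay for inhibition of alpha-N-acetylgalactosaminidase (Gallus gallus), tested at 1000 uM; a higher number here means more inhibition at the concentration tested (going by the name of the read-out), a lower number less inhibition:

- compound 1, `O=C(O)[C@H]1NC[C@H](O)[C@@H](O)[C@H]1O`, compound 1 gives 31%
- compound 2, `O=C(O)[C@@H]1NC[C@@H](O)[C@H](O)[C@@H]1O`, compound 2 gives 10%

Compound 2 stands at the lower of the two numbers in this assay. For the measured compounds named here, the only measured step leads to it: a number 21 percentage points lower from compound 1 to compound 2 (beyond the scatter). The two compounds are mirror images of each other, and the change in this assay rests on the fact that compounds 1 and 2 differ only in the configuration as drawn alone, so a rearrangement of the stereocentres, with nothing else altered, is enough to move the read-out by this amount.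

Compound 3, `O=C(O)[C@@H]1NC[C@H](O)[C@H](O)[C@H]1O`, has not yet been measured in this assay. It differs from compound 2 in this way: the two compounds have the same atoms and bonds and differ only in configuration as drawn: 2 of 4 stereo elements differ; a stereocentre at a saturated ring carbon is drawn R in compound 2 and S in compound 3; a stereocentre at a saturated ring carbon is drawn R in compound 2 and S in compound 3. Compound 3 is therefore neither the mirror image of compound 2 nor that of compound 1; it shares two stereocentres with each. Going by the values given here, the one measured step shows that configuration matters here, but it gives no direction for a partial inversion. The expected step is a number 8 percentage points higher from compound 2 to compound 3 (within the scatter), taken as a move toward the middle ground between the two measured compounds. Compound 3 is thus estimated at 18%, with a range from 0% to 45%.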

Compound 3, a percentage reported as inhibition, at one concentration (the size of the read-out at that concentration, not a potency): 4.4%
Compound 3: the middle estimate sits 13.6 percentage points above what was measured, and the stated range covers the measured number.
By their numbers in this assay, from the lowest: compounds 3 and 2 (each within the scatter of the next); then compound 1.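

In this assay, inverting two stereocentres on the shared core need not move the read-out beyond the usual variation, as the result is a number 5.6 percentage points lower from compound 2 to compound 3 (within the scatter). A different pair of inverted stereocentres has a clear effect, giving a number 26.6 percentage points lower from compound 1 to compound 3 (beyond the scatter), so inverting all four stereocentres is not needed for a step beyond the scatter from compound 1. That step rests on one thing only: the fact that compounds 1 and 3 differ only in the configuration as drawn.

It remains open which single stereocentre, if any, accounts for most of the step, since each pair of compounds here differs at two or four stereocentres at once. Also open, as far as these compounds go, is how the read-out in this assay would respond if a hydroxymethyl group or a methyl ester took the place of the carboxylic acid on the configuration of compound 1.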